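The compounds below may be only part of what the source reports. "The series", "measured", "known", "first", "only" and "open" are said of these compounds alone.

The compounds measured so far:
compound 1, `CC(C)=CCC/C(C)=C/COc1ccc(C2CC2C(=O)NNC(=O)c2ccncc2)cc1`: in a functional assay on MCF7 cells (Homo sapiens) for inhibition, read by MTT assay, with a stated time of 72 h (a higher number here means a weaker inhibitor, a lower number a stronger inhibitor), compound 1 has no result, "not determined" (no result reported).
compound 2, `COc1ccc(C2CC2C(=O)NNc2nncc3ccccc23)cc1`: in this assay compound 2 gives 72000 nM.

Going by the values given here, compound 2 therefore stands alone with the only number in this assay; compound 1 offers nothing to set beside it, so there is no measured step within this small set and no sense yet of how the series moves.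

Compound 3, `CC(C)=CCC/C(C)=C/COc1ccc(C2CC2C(=O)NNc2nncc3ccccc23)cc1`, is the next compound for this assay. It is built from compound 2 by one change: 2,6-dimethylhepta-1,5-dien-1-yl in place of hydrogen on a saturated chain carbon bound to an oxygen on an aromatic ring. The same chain is already present in compound 1, but since compound 1 carries no number, the effect of the chain in this assay has not been seen in any pair here.

Among the compounds with values here, with no measured step to lean on, the direction can only be guessed. A modest gain in potency is expected, somewhat beyond the scatter, so that the step of a 2.4-fold lower number from compound 2 to compound 3 (0.38 log units; beyond the scatter) is estimated as a move toward stronger inhibition. Compound 3 is accordingly expected to give about 30000 nM in this assay, within a range from 8000 nM to 100000 nM.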

Compound 3, half-maximal inhibitory concentration: 23000 nM
Estimate against measurement, compound 3: 1.3-fold (0.12 log units) above, within the range that was stated.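

Going from methoxy to (3,7-dimethylocta-2,6-dien-1-yl)oxy gives a 3.1-fold lower number from compound 2 to compound 3 (0.50 log units; beyond the scatter) in this assay, the first measured step in this set and the first reading of what this chain does at this position, which compound 1 could not supply. The position on the saturated chain carbon bound to an oxygen on an aromatic ring therefore accepts a far larger group than a methyl with a modest move toward stronger inhibition, although the gain is small enough that compound 3 remains a weak inhibitor at 23000 nM in this assay. Nothing shown here gives a reason for this step.

As far as these compounds go, whether the whole of the chain is needed stays open, since a shorter 3-methylbut-2-en-1-yl group, a fully saturated decyl chain or an amine or carboxylic acid at the chain end could each move the number differently. From the compounds shown here alone, it also remains open whether the step would carry over to the other end of the molecule as it stands in compound 1, which offers no number to set against compound 3.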